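The compounds below may be only part of what the source reports. "The series", "measured", "known", "first", "only" and "open" are said of these compounds alone.

Measured in a functional assay on HepG2 cells (Homo sapiens) for inhibition, read by sulforhodamine B assay, with a stated time of 72 h; on this read-out lower numbers stand for stronger inhibition and higher numbers for weaker inhibition:
- Compound 1 `C[C@H](Nc1nc(N)nc(N)c1C#N)c1nn(-c2cccc(S(C)(=O)=O)c2)c2cc(F)ccc12`: 19100 nM
- Compound 2 `Cc1ccc2c(c1)c([C@H](C)Nc1ncnc3[nH]cnc13)nn2-c1cccnc1`: > 40000 nM (a limit of the assay, not a number)
- Compound 3 `C[C@H](Nc1nc(N)nc(N)c1C#N)c1nn(-c2cccnc2)c2cc(C(F)(F)F)ccc12`: 1680 nM

Within the data shown here, only two of these readings are true numbers. Compound 1 gives 19100 nM, the higher of the two, and compound 3 gives 1680 nM. That gap lies beyond the usual scatter of repeat measurements, so compound 1 is the weaker inhibitor of this pair. The remaining reading is the limit of > 40000 nM in this assay, at which 1 of the 3 values shown sits.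

Compound 4 `C[C@H](Nc1ncnc2[nH]cnc12)c1nn(-c2cccc(S(C)(=O)=O)c2)c2cc(F)ccc12` has not yet been measured in this assay. Compared with compound 1, it replaces the 2,6-diamino-5-cyanopyrimidin-4-yl group, on an amine nitrogen, with a group that has no common name: a group of 9 heavy atoms (5 carbon, 4 nitrogen; one five-membered aromatic ring with 2 hetero atoms, one six-membered aromatic ring with 2 hetero atoms) in place of a group of 10 heavy atoms (5 carbon, 5 nitrogen; one six-membered aromatic ring with 2 hetero atoms), on an amine nitrogen.

The same entering group is found on compound 2, which reads > 40000 nM, and this reading is a limit. Among the measured compounds shown here, this is the main reason to expect a higher number, though compound 2 also differs elsewhere and is only one example. The expected change is small and may not exceed the scatter: a 1.7-fold higher number from compound 1 to compound 4 (0.22 log units; within the scatter). Compound 4 could also return only a limit. For compound 4 the estimate is 32000 nM, with an expected range from 12000 nM to 40000 nM.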

Compound 4, half-maximal inhibitory concentration: 14800 nM
Compound 4: the middle estimate sits 2.2-fold (0.33 log units) above what was measured; measured number inside the range.
By their numbers in this assay, from the lowest: compound 3; then compounds 4 and 1 (each within the scatter of the next). At a limit, above all of these: compound 2.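

Among these compounds, this is the first matched pair in the set, and it isolates the group on the amine nitrogen, with everything else in the molecule unchanged. In this assay, putting the group with one five-membered and one six-membered aromatic ring in place of the 2,6-diamino-5-cyanopyrimidin-4-yl group gives a 1.3-fold lower number from compound 1 to compound 4 (0.11 log units; within the scatter), so on this core the two groups cannot be told apart, despite the loss of the nitrile and the different ring system. Compound 2 carries the same entering group but also differs elsewhere, so it gives no clean comparison with compound 4, and its reading remains a limit: the limit of > 40000 nM in this assay, at which 1 of the 4 values shown sits.

The compounds shown leave open whether the two groups would also match on the core of compound 3, the only compound here with a reading clearly stronger than the others, since no matched pair covers that core. They also leave open how the reading would respond if an amine or a carboxylic acid took the place of the methylsulfonyl group shared by compound 1 and compound 4.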